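Dropping One Methoxy Group: From Compound 1 to Compound 3

The source may report more compounds than this note shows. Statements on the series, on what has been measured and on what is new or still open speak of the compounds shown alone.

Compound 1 `COc1ccc(CNc2nc3cc(N)cc(N)c3nc2-c2ccccc2)cc1OC` gives 63100 nM in a functional assay on NCI-H522 cells (Homo sapiens) for inhibition, read by sulforhodamine B assay, with a stated time of 48 h; on this read-out lower numbers stand for higher toxicity in this test and higher numbers for lower toxicity in this test.
Compound 2 `COc1cc(CNc2nc3cc(N)cc(N)c3nc2-c2ccccc2)cc(OC)c1OC` gives only a limit in this assay, < 50200 nM.
Compound 3 `COc1ccc(CNc2nc3cc(N)cc(N)c3nc2-c2ccccc2)cc1` has not yet been tested in this assay.

Going by the values given here, compound 1 stands as the only plain number among the values shown; the other value is a limit (the limit of < 50200 nM in this assay, at which 1 of the 2 values shown sits). The change from compound 1 to compound 3 is hydrogen in place of methoxy on an aromatic carbon. Among the compounds with values here, only one measured step touches on a methoxy group: an at least 1.2-fold lower number from compound 1 to compound 2 (0.09 log units; that floor lies within the scatter). That step runs in the opposite direction, a methoxy entering rather than leaving, and its floor lies within the scatter, so it gives no sign that a methoxy group on this ring shifts the number by much. Compound 3 is therefore expected to move only a 1.1-fold higher number from compound 1 to compound 3 (0.05 log units; within the scatter), no more than the scatter allows. Compound 3 is estimated at 70000 nM, with a range from 30000 nM to 160000 nM.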

Compound 3, concentration lethal to 50% of the cells: 47900 nM
The estimate for compound 3 lay 1.5-fold (0.16 log units) above the measured number; the range from low to high includes it.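

In this assay, the change from 3,4-dimethoxyphenyl to 4-methoxyphenyl gives a 1.3-fold lower number from compound 1 to compound 3 (0.12 log units; within the scatter), so this methoxy group, ortho to a methoxy group, can give way to hydrogen without a step beyond the scatter. Going by these compounds alone, this is the first step read between two plain numbers, and it concerns a methoxy group leaving rather than entering. Compound 2 still gives only a limit, so the earlier step offers nothing but a floor: the limit of < 50200 nM in this assay, at which 1 of the 3 values shown sits.

The compounds shown leave open whether an amine, a carboxylic acid or a longer chain such as ethoxy at this place would give a step beyond the scatter. They also leave open what happens when the remaining methoxy group of compound 3 gives way to hydrogen.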